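A few compounds are considered here, and "the series" means these few. Any claim that something is new, unique, unknown or untested is made for them only; others in the source may bear on it.

Measured so far in a functional assay on HCT-116 cells (Homo sapiens) for antiproliferative activity, with a stated time of 72 h; on this read-out lower numbers stand for stronger inhibition and higher numbers for weaker inhibition:
- compound 1, `Nc1ncnn2c([C@@H]3O[C@H](CO)[C@@H](O)[C@H]3O)cc(C#Cc3ccccc3)c12`: 46900 nM
- compound 2, `Nc1ncnn2c([C@@H]3O[C@H](CO)[C@@H](O)[C@H]3O)cc(-c3ccccc3)c12`: 82600 nM
- compound 3, `Cc1ccccc1-c1cc([C@@H]2O[C@H](CO)[C@@H](O)[C@H]2O)n2ncnc(N)c12`: only a limit, > 100000 nM

All three share one core and differ only in the group on an aromatic carbon. Compound 2 carries the higher of the two numbers that were obtained, and a 1.8-fold higher number from compound 1 to compound 2 (0.25 log units; within the scatter) shows that compound 1 is not separated from it by more than the usual scatter. Compound 3 did not yield a number at all; it sits at the limit (the limit of > 100000 nM in this assay, at which 1 of the 3 values shown sits).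

Compound 4, `Nc1ncnn2c([C@@H]3O[C@H](CO)[C@@H](O)[C@H]3O)cc(-c3ccccc3Cl)c12`, is built from compound 2 by the change (chloro in place of hydrogen on an aromatic carbon). The step that bears most directly on it is an at least 1.2-fold higher number from compound 2 to compound 3 (0.08 log units; that floor lies within the scatter), where a methyl in place of hydrogen on the same aromatic carbon pushed the result past the limit; the step of an at least 2.1-fold higher number from compound 1 to compound 3 (0.32 log units; beyond the scatter) points the same way. A chloro is a single heavy atom in the same position, so the same outcome is expected: a weakening step of modest size in this assay, with a real chance that only a limit will be reported.

For compound 4 the expected value in this assay is 140000 nM, within 60000 nM to 350000 nM, which corresponds to the expected step of a 1.7-fold higher number from compound 2 to compound 4 (0.23 log units; within the scatter).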

Compound 4, half-maximal inhibitory concentration: > 100000 nM
Compound 4 gave a limit, no number; the forecaster's own chance of this, stated with the estimate: 55%; the middle value does not contradict the limit.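

In this assay compound 4, like compound 3, gives a limit and not a number, so two different groups ortho to a large group, chloro and methyl, now end the same way: the limit of > 100000 nM in this assay, at which 2 of the 4 values shown sit.

The chloro change itself gives an at least 1.2-fold higher number from compound 2 to compound 4 (0.08 log units; that floor lies within the scatter), which leaves the size of its effect unresolved, while the comparison with the 2-phenylethynyl compound gives an at least 2.1-fold higher number from compound 1 to compound 4 (0.32 log units; beyond the scatter), so this second substituted phenyl also stands apart from compound 1 by more than the scatter. The step between compound 3 and compound 4 cannot be read, as both are limits, and methyl and chloro therefore cannot be ranked against each other here.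

On these data alone, what numbers lie behind the two limits remains unknown, so neither compound 3 nor compound 4 can be placed exactly. As far as these compounds go, it also remains open whether another group at this ortho place, such as an amine, a methoxy or a carboxylic acid, would return a measurable number in this assay, and whether a longer chain in place of the 2-phenylethynyl group of compound 1 would change it.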